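The source may hold more compounds than are shown below. What is called first, only, known or untested is meant among the compounds shown, and "the series" means these compounds.

In a functional assay on NCI-H460 cells (Homo sapiens) for inhibition, read by MTT assay, with a stated time of 72 h (on this read-out higher numbers stand for weaker inhibition of growth and lower numbers for stronger inhibition of growth), the measured compounds stand as follows.
Compound 1 `N#C/C(=C\c1c(F)c(F)c(F)c(F)c1F)C(=O)c1ccc[nH]1` gives 31000 nM.
Compound 2 `COc1ccc(CNC(=O)/C(C#N)=C/c2ccc[nH]2)cc1` gives only a limit, > 50000 nM.
Compound 3 `COc1ccc(CNC(=O)/C(C#N)=C/c2ccc(C)o2)cc1` gives only a limit, > 100000 nM.

Compound 3 thus sits at a limit of this assay, the one marked by the limit of > 100000 nM in this assay, at which 1 of the 3 values shown sits, so its place among the numbers cannot be fixed. Among the compounds with values here, the single measured step that touches it, a step that the two limits leave unreadable from compound 2 to compound 3, is left unreadable by the two limits the limit of > 100000 nM in this assay, at which 1 of the 3 values shown sits, and (the limit of > 50000 nM in this assay, at which 1 of the 3 values shown sits). Compound 4 `COc1ccc(CNC(=O)/C(C#N)=C/c2ccc(Br)o2)cc1` differs from compound 3 by bromo in place of methyl on an aromatic carbon. Within the data shown here, no measured step in this assay bears on this exchange, so neither size nor direction can be drawn from the data. Because compound 3 sits at > 100000 nM, compound 4 is expected to stay near that limit. The step of a number no higher from compound 3 to compound 4 (the limit leaves the size open) is estimated to be none beyond the scatter. For compound 4 the estimate is 100000 nM, with a range from 30000 nM to 300000 nM.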

Compound 4, concentration for 50% growth inhibition: 16000 nM
The estimate for compound 4 lay 6.3-fold (0.80 log units) above the measured number; the whole stated range lies above it.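

In this assay, within the data shown here, bromo on this aromatic carbon next to the ring oxygen gives stronger inhibition of growth than methyl, a change the earlier compounds could not show: an at least 6.2-fold lower number from compound 3 to compound 4 (0.79 log units; beyond the scatter). The 5-bromofuran-2-yl group also compares readably with 1H-pyrrol-2-yl, giving an at least 3.1-fold lower number from compound 2 to compound 4 (0.49 log units; beyond the scatter). Each size is only a minimum, and the first rests on a limit of the assay: the limit of > 100000 nM in this assay, at which 1 of the 4 values shown sits.

As far as these compounds go, it remains open whether chloro or an amine at this carbon would match bromo. From the compounds shown here alone, it also remains open whether bromo on the pyrrole ring of compound 2 would give a similar step.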